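The source may report more compounds than this note shows. Statements on the series, on what has been measured and on what is new or still open speak of the compounds shown alone.

Measured compounds:
Compound 1 `N#CC1=C(N)Oc2c(N)cc3nc4ccccc4nc3c2C12C(=O)N(Cc1cnnn1-c1cccc(Br)c1)c1ccccc12` gives > 50000 nM in an ADME assay on HUVEC cells (Homo sapiens) for antiproliferative activity, read by MTT assay, with a stated time of 48 h; on this read-out higher numbers stand for weaker inhibition and lower numbers for stronger inhibition.
Compound 2 `CCc1cccc(C)c1-n1nncc1CN1C(=O)C2(C(C#N)=C(N)Oc3c(N)cc4nc5ccccc5nc4c32)c2ccccc21` gives > 50000 nM in this assay.

Each of these values is a limit of the assay and not a number; the step that the two limits leave unreadable from compound 1 to compound 2 is accordingly unreadable, as the limit of > 50000 nM in this assay, at which 2 of the 2 values shown sit, records. Compound 2 thus stands at the assay limit, and nothing in the numbers sets it apart from compound 1.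

Compound 3 `N#CC1=C(N)Oc2c(N)cc3nc4ccccc4nc3c2C12C(=O)N(Cc1cnnn1-c1ccc([N+](=O)[O-])cc1[N+](=O)[O-])c1ccccc12` has not yet been measured. It differs from compound 2 by 2,4-dinitrophenyl in place of 2-ethyl-6-methylphenyl on an aromatic nitrogen. Within the data shown here, the only measured step, from compound 1 to compound 2, concerns the same aromatic nitrogen, where one aryl group replaced another, and the two limits leave its size unreadable. It bears on the present change only in that exchanging the aryl at this nitrogen left both compounds at the limit. No step beyond the scatter in this assay is expected in either direction, and a limit is the most likely outcome again. Compound 3 is estimated at 60000 nM, with a range of 20000 nM to 200000 nM, the step that the limit leaves unreadable from compound 2 to compound 3 being an expectation only.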

Compound 3, half-maximal inhibitory concentration: > 50000 nM
Compound 3 ended at the assay's limit; the forecaster's own chance of this, stated with the estimate: 80%; the middle value does not contradict the limit.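

In this assay compound 3 gives > 50000 nM, a limit of the assay and not a number. Among these compounds, no step from compound 1 or compound 2 to compound 3 can be read: the limit of > 50000 nM in this assay, at which 3 of the 3 values shown sit. The compounds shown leave open how compound 1, compound 2 and compound 3 rank, and whether any aryl group on this aromatic nitrogen gives a measurable value in this assay.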